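Compound 1: methyl in place of hydrogen on nitrogen

The source may report more compounds than this note shows. Statements on the series, on what has been measured and on what is new or still open speak of the compounds shown alone.

In a functional assay on KBVIN cells (Homo sapiens) for antiproliferative activity, read by sulforhodamine B assay, with a stated time of 48 h (a lower number here means a stronger inhibitor of growth, a higher number a weaker inhibitor of growth), compound 1 (`COc1ccc(Nc2nc(NC3CCCC3)c3ccccc3n2)cc1`) gives 12600 nM and compound 2 (`COc1ccc(Nc2nc(NC3CC3)c3ccccc3n2)cc1`) gives 13400 nM, values within the scatter of each other. Compound 3 (`COc1ccc(N(C)c2nc(NC3CCCC3)c3ccccc3n2)cc1`) differs from compound 1 by one change: methyl in place of hydrogen on a nitrogen on an aromatic ring. Going by the values given here, the only measured step, a 1.1-fold higher number from compound 1 to compound 2 (0.03 log units; within the scatter), concerns a different nitrogen and gives little guidance here. Among the compounds with values here, no measured step touches this nitrogen, so the direction remains open, with a tentative lean towards a lower number in this assay. The expected step is a 2.5-fold lower number from compound 1 to compound 3 (0.40 log units; beyond the scatter). For compound 3 the estimated value is 5000 nM, with an expected range of 500 nM to 20000 nM.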

Compound 3, concentration for 50% growth inhibition: 10100 nM
Compound 3: middle estimate off by 2.0-fold (0.31 log units), on the low side; low and high end bracket the measured number.
By their numbers in this assay, from the lowest: compounds 3, 1 and 2 (each within the scatter of the next).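

In this assay, going by these compounds alone, methyl in place of hydrogen on a nitrogen on an aromatic ring gives a 1.2-fold lower number from compound 1 to compound 3 (0.10 log units; within the scatter) and is the first measured change at this nitrogen. The hydrogen here can therefore be replaced by methyl with no change beyond the scatter. No measurement on hand explains this result.

Still open, as far as these compounds go, is whether ethyl, a longer chain or an acetyl on this nitrogen would also leave the number within the scatter. Also open, from the compounds shown here alone, is whether methyl here gives the same result with cyclopropyl in place of cyclopentyl.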